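Aryl ketone series: halogen exchange on the benzoyl ring

The source may report more compounds than this note shows. Statements on the series, on what has been measured and on what is new or still open speak of the compounds shown alone.

Measured so far:
compound 1 `COc1cc(OC)c(C(=O)c2cccc(Cl)c2)c(O)c1CN1CCCCC1` — 83%
compound 2 `COc1cc(OC)c(C(=O)c2ccccc2F)c(O)c1CN1CCCC1` — 87%

In a functional assay on THP-1 cells (Homo sapiens) for inhibition, read by ELISA, with stated times of 30 min and 24 h, tested at 10 uM (on this read-out higher numbers stand for a stronger effect at the one concentration tested and lower numbers for a weaker effect), compound 1 gives 83% and compound 2 gives 87%. The two numbers lie within the scatter of each other, so compound 2 cannot be set apart from compound 1 on what has been measured; both sit near the top of the scale at the single concentration tested. Within the data shown here, no step between measured compounds that differ in one place is available, so nothing yet shows how a single change on the benzoyl ring moves the read-out.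

Compound 3 `COc1cc(OC)c(C(=O)c2ccccc2Br)c(O)c1CN1CCCC1` is not yet measured. It differs from compound 2 as follows:

bromo in place of fluoro on an aromatic carbon

Given that compound 2 and compound 1 both read high in this assay, a halogen exchange at the same place is expected to leave the read-out within the scatter, and the expected step of a number 2 percentage points lower from compound 2 to compound 3 (within the scatter) is therefore one of no size beyond the usual spread. The estimate for compound 3 in this assay is 85%, with a range from 65% to 95%.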

Compound 3, a percentage reported as activity, at one concentration (the size of the read-out at that concentration, not a potency): 100%
The estimate for compound 3 lay 15 percentage points below the measured number; the measured number lies above the stated range.
By their numbers in this assay, from the lowest: compounds 1 and 2 (each within the scatter of the next); then compound 3.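

In this assay, among these compounds, the read-out moves by a number 13 percentage points higher from compound 2 to compound 3 (beyond the scatter) with bromo in place of fluoro on an aromatic carbon ortho to a large group, the first change that can be read at a single place. The identity of the halogen at this place therefore matters, since the exchange from 2-fluorophenyl to 2-bromophenyl gives a step beyond the scatter, with compound 3 at 100% in this assay at the one concentration tested. Nothing at hand accounts for the step.

From the compounds shown here alone, whether this step reflects a trend across the halogens or is particular to bromo remains open, as does the outcome with iodo, methyl, methoxy or trifluoromethyl at the same place. As the read-out gives the size of the effect at one concentration, the potency of compound 3 relative to compound 2 and whether the same exchange gives a similar step on a different amine side chain also remain unresolved.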